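Working notes: stepping from compound 2 to compound 3

The source may report more compounds than this note shows. Statements on the series, on what has been measured and on what is new or still open speak of the compounds shown alone.

In an ADME assay on HEK293 cells (Homo sapiens) for cytotoxicity, read by reporter gene assay and resazurin assay, with a stated time of 48 h (on this read-out higher numbers stand for lower toxicity in this test and lower numbers for higher toxicity in this test), compound 1 (`O=C(Nc1ccc(Sc2nc3ccccc3s2)c(Cl)c1)c1cccc(Br)c1`) gives > 100000 nM, which is a limit of the assay and not a number. Within the data shown here, compound 2 (`O=C(Nc1ccc(Sc2nc3ccccc3s2)c(Cl)c1)c1cc(Br)ccc1O`) gives 45000 nM, the only actual number so far. Compound 3 (`O=C(Nc1ccc(Sc2nc3ccccc3s2)c(Cl)c1)c1ccccc1`) is not yet measured. The change is phenyl in place of 5-bromo-2-hydroxyphenyl on a carbonyl carbon. Among the measured compounds shown here, one measured step bears on this: an at least 2.2-fold lower number from compound 1 to compound 2 (0.34 log units; beyond the scatter), with hydroxy in place of hydrogen on an aromatic carbon. As far as these compounds go, its full size stays open because of the limit of > 100000 nM in this assay, at which 1 of the 2 values shown sits. For the measured compounds named here, no measured step isolates the loss of the bromine. Compound 3 has no hydroxy, so that step is expected to reverse, giving a higher number in this assay. The expected change is a 2.0-fold higher number from compound 2 to compound 3 (0.30 log units; within the scatter). The estimated value for compound 3 is 90000 nM, with an expected range of 40000 nM to 200000 nM.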

Compound 3, half-maximal cytotoxic concentration: 90000 nM
Compound 3: middle estimate and measured number agree at the digits printed; the measured number falls inside the stated range.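

Phenyl in place of 5-bromo-2-hydroxyphenyl on the carbonyl carbon gives, in this assay, a 2.0-fold higher number from compound 2 to compound 3 (0.30 log units; within the scatter), so removing both groups from this ring leaves no change that can be told apart from the scatter. Compound 3 also gives this position an actual number for the plain phenyl, and hydrogen in place of bromo on an aromatic carbon now has a step of its own: an at least 1.1-fold lower number from compound 1 to compound 3 (0.04 log units; that floor lies within the scatter). That step gives only a floor, and its full size cannot be read: the limit of > 100000 nM in this assay, at which 1 of the 3 values shown sits.

As far as these compounds go, the effect of the hydroxy on a ring without bromo stays open. Also open, from the compounds shown here alone, is how an amine or a carboxylic acid on this phenyl, or a longer chain in its place, would read in this assay.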